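A few compounds are considered here, and "the series" means these few. Any claim that something is new, unique, unknown or untested is made for them only; others in the source may bear on it.

Compound 1 `COc1ccc(/C=C2\S/C(=N\c3ccccc3)N(Cc3ccco3)C2=O)cc1OC`: > 400000 nM
Compound 2 `O=C1/C(=C/c2cccc([N+](=O)[O-])c2)S/C(=N\c2ccccc2)N1Cc1ccco1`: "not determined" (no result reported)
Compound 3 `O=C1/C(=C/c2ccc([N+](=O)[O-])cc2)S/C(=N\c2ccccc2)N1Cc1ccco1`: "not determined" (no result reported)

In a toxicity assay on CHO cells (Cricetulus griseus) for cytotoxicity, read by MTT assay, with a stated time of 48 h (on this read-out lower numbers stand for stronger inhibition and higher numbers for weaker inhibition), compound 1 gives > 400000 nM, which is a limit of the assay and not a number. Compound 2 has no figure either, and the entry for compound 3 reads "not determined" (no result reported). Among the measured compounds shown here, compound 3 therefore has no place on the scale, and the only reading nearby is the limit of > 400000 nM in this assay, at which 1 of the 3 values shown sits.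

The next structure is compound 4 `O=C1/C(=C/c2ccc(O)cc2)S/C(=N\c2ccccc2)N1Cc1ccco1`. The change is hydroxy in place of nitro on an aromatic carbon. In words, this is hydroxy in place of nitro on an aromatic carbon, para to a large group, turning 4-nitrophenyl into 4-hydroxyphenyl.

For the measured compounds named here, no measured pair shows what a change of this kind does, and compound 3 offers no number to start from. Going by the values given here, the expectation in this assay is therefore no step beyond the usual scatter, in either direction, with the reading of compound 1 as the only guide. For compound 4 the estimated value is 300000 nM, with an expected range from 100000 nM to 800000 nM.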

Compound 4, half-maximal inhibitory concentration: 400000 nM
Compound 4: middle estimate off by 1.3-fold (0.12 log units), on the low side, and the stated range covers the measured number.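

Among the compounds shown here, with 4-hydroxyphenyl at this position, compound 4 gives 400000 nM in this assay, the first actual number and a high one on a scale where higher means weaker inhibition. Compound 3 has no result, so the change from 4-nitrophenyl to 4-hydroxyphenyl cannot be given a size. The change from 3,4-dimethoxyphenyl to 4-hydroxyphenyl gives a number no higher from compound 1 to compound 4 (the limit leaves the size open). The reading of compound 1 is a limit of the assay and not a number: the limit of > 400000 nM in this assay, at which 1 of the 4 values shown sits.

From the compounds shown here alone, it remains open whether any group on this aromatic carbon would bring the number clearly lower in this assay. Going by these compounds, an amine or a carboxylic acid in place of the hydroxy would test this, and the effect of nitro itself remains unknown.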